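The source may hold more compounds than are shown below. What is called first, only, known or untested is meant among the compounds shown, and "the series" means these compounds.

In an ADME assay on the whole organism for cytotoxicity, with Artemia salina as the target, with a stated time of 24 h (on this read-out lower numbers stand for an effect already at smaller amounts and higher numbers for an effect only at larger amounts of compound), compound 2 `Cc1ccc(/C=C/C(=O)c2ccccc2NC(=O)NS(=O)(=O)c2ccc(C)cc2)cc1` gives 15.3 ug/mL. Compound 1 `Cc1ccc(S(=O)(=O)NC(=O)Nc2ccccc2C(=O)/C=C/c2ccccc2)cc1` gives 25 ug/mL, and a 1.6-fold lower number from compound 1 to compound 2 (0.21 log units; within the scatter). Compound 3 `C=CCOc1ccc(/C=C/C(=O)c2ccccc2NC(=O)NS(=O)(=O)c2ccc(C)cc2)cc1` gives 6.11 ug/mL, with a 2.5-fold lower number from compound 2 to compound 3 (0.40 log units; beyond the scatter) and a 4.1-fold lower number from compound 1 to compound 3 (0.61 log units; beyond the scatter); compound 2 thus sits between these two, close to compound 1 and set apart from compound 3. Compound 4 `Cc1ccc(S(=O)(=O)NC(=O)Nc2ccccc2C(=O)/C=C/c2cccnc2)cc1` differs from compound 2 by pyridin-3-yl in place of 4-methylphenyl on a double-bonded chain carbon bound to a double-bonded chain carbon. Going by the values given here, none of the measured steps replaces one aromatic ring by another; each only changes a group on an aromatic carbon, and those steps shift the numbers modestly at most. Among the compounds with values here, no measured step therefore bears directly on this exchange, and no shift beyond the scatter in this assay is expected. Compound 4 is estimated at 22 ug/mL (range 10 ug/mL to 50 ug/mL), an expected 1.4-fold higher number from compound 2 to compound 4 (0.16 log units; within the scatter).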

Compound 4, concentration for half-maximal effect: 14.1 ug/mL
Estimate against measurement, compound 4: 1.6-fold (0.19 log units) above, within the range that was stated.
By their numbers in this assay, from the lowest: compound 3; then compounds 4, 2 and 1 (each within the scatter of the next).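

In this assay pyridin-3-yl on a double-bonded chain carbon bound to a double-bonded chain carbon, the only ring exchange shown, stays within the scatter against 4-methylphenyl (a 1.1-fold lower number from compound 2 to compound 4 (0.04 log units; within the scatter)) and phenyl (a 1.8-fold lower number from compound 1 to compound 4 (0.25 log units; within the scatter)). Against 4-(allyloxy)phenyl the same exchange goes beyond the scatter (a 2.3-fold higher number from compound 3 to compound 4 (0.36 log units; beyond the scatter)), so among these aromatic groups only that of compound 3 stands apart. No measurement on hand accounts for these steps. Still open, from the compounds shown here alone, is whether pyridin-2-yl or pyridin-4-yl at this place would match compound 4, and how an amine or a carboxylic acid on the phenyl ring would read.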